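Swapping a Benzylic Alcohol for a Phenyl Ether

This account rests on a few compounds, and the source may have more. Where it says the series, first, only, none or still open, it means among the compounds named here.

Compound 1, `CCS(=O)(=O)N(Cc1cccnc1)c1ccc(C(O)c2ccccc2)cc1`: > 30000 nM
Compound 2, `CCS(=O)(=O)N(Cc1cccnc1)c1cccc(C(O)c2ccccc2)c1`: 2500 nM
Compound 3, `CCS(=O)(=O)N(Cc1cccnc1)c1ccc(Cc2ccccc2)cc1`: 1600 nM

Of the compounds shown here, three sharing one core have been tested in an assay on isolated protein with metabotropic glutamate receptor 2 (Homo sapiens) as the target; a higher number here means that more compound is needed for the effect, a lower number that less compound is needed. Compound 1 reaches only the limit of this assay and gives no number, > 30000 nM. Compound 2 gives 2500 nM, the highest of the two numbers available. Compound 3 gives 1600 nM, which lies within the scatter of compound 2, so the two cannot be told apart. One measured step changes a single place: an at least 18-fold lower number from compound 1 to compound 3 (1.27 log units; beyond the scatter). Because that step rests on (the limit of > 30000 nM in this assay, at which 1 of the 3 values shown sits), only its lower bound is known.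

Compound 4, `CCS(=O)(=O)N(Cc1cccnc1)c1cccc(COc2ccccc2)c1`, has not yet been measured. Compared with compound 2, (phenoxymethyl in place of hydroxy(phenyl)methyl on an aromatic carbon). This change shares one feature with the measured step from compound 1 to compound 3: the hydroxy group on the saturated chain carbon disappears, and compound 4 keeps no hydrogen-bond donor in that part of the molecule. That measured step gave a large fall in the number, which points toward a lower number for compound 4 as well, though the surrounding structure is not the same and the size of the effect is uncertain. Compound 4 is therefore expected to give 900 nM, with a likely range from 250 nM to 3500 nM. The expected step is a 2.8-fold lower number from compound 2 to compound 4 (0.44 log units; beyond the scatter).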

Compound 4, half-maximal effective concentration: 160 nM
For compound 4 the middle estimate is 5.6-fold (0.75 log units) above the measured one; the whole stated range lies above it.
By their numbers in this assay, from the lowest: compound 4; then compounds 3 and 2 (each within the scatter of the next). At a limit, above all of these: compound 1.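

In this assay, the change on this aromatic carbon gives a 16-fold lower number from compound 2 to compound 4 (1.19 log units; beyond the scatter), so a large shift occurs even though compound 2 and compound 4 contain the same atoms, joined differently. The earlier step that removed a hydroxy group also took its oxygen away, whereas here the oxygen stays in the molecule: phenoxymethyl has the same heavy-atom count and the same single hydrogen-bond acceptor as hydroxy(phenyl)methyl, and it differs in having no hydrogen-bond donor and in how the two parts are linked. The size of this step cannot be set against that earlier one, of which only a lower bound is known: the limit of > 30000 nM in this assay, at which 1 of the 4 values shown sits.

Among the compounds shown here, the pair cannot separate the loss of the hydrogen-bond donor from the new way of joining the phenyl ring, since both change together in the single step from hydroxy(phenyl)methyl to phenoxymethyl. The compounds shown also leave open how the number in this assay would respond to an amine or a sulfur atom in place of the ether oxygen, or to a longer chain between the two rings.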